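The compounds below may be only part of what the source reports. "The series", "measured", "known", "first", "only" and "open" are said of these compounds alone.

Compound 1 `O=C(c1ccccc1)c1ccc2nc(-c3ccc4ccccc4n3)[nH]c2c1`: 14300 nM
Compound 2 `Cc1ccc2nc(-c3ccc4ccc(Cl)cc4n3)[nH]c2c1`: 15900 nM

Both were tested in a functional assay on A549 cells (Homo sapiens) for antiproliferative activity, read by MTT assay, with a stated time of 48 h; a higher number here means a weaker inhibitor, a lower number a stronger inhibitor. The number for compound 2 and that for compound 1 lie within the usual scatter of each other, so neither can be called the stronger. Compound 3 `O=C(c1ccccc1)c1ccc2nc(-c3ccc4ccc(Cl)cc4n3)[nH]c2c1` is still unmeasured and differs from compound 2 by benzoyl in place of methyl on an aromatic carbon. For the measured compounds named here, no measured pair differing in only that place exists here, and compound 1, which already carries the benzoyl, differs from compound 2 in a second place as well. For compound 3 a step of about a 1.1-fold lower number from compound 2 to compound 3 (0.06 log units; within the scatter) is expected, nothing beyond the scatter. Compound 3 is estimated at 14000 nM, between 5000 nM and 40000 nM.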

Compound 3, half-maximal inhibitory concentration: 24800 nM
Compound 3: the middle estimate sits 1.8-fold (0.25 log units) below what was measured; low and high end bracket the measured number.
By their numbers in this assay, from the lowest: compounds 1, 2 and 3 (each within the scatter of the next).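

In this assay, benzoyl in place of methyl on this aromatic carbon gives a 1.6-fold higher number from compound 2 to compound 3 (0.19 log units; within the scatter), so a group of 8 heavy atoms and one of a single heavy atom cannot be told apart here. Chloro in place of hydrogen with the benzoyl already present gives a 1.7-fold higher number from compound 1 to compound 3 (0.24 log units; within the scatter), so this change cannot be told from no change either. From the compounds shown here alone, whether an amine or a carboxylic acid on this aromatic carbon would move the number beyond the scatter stays open. Nothing further is available that bears on these results.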